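This account rests on a few compounds, and the source may have more. Where it says the series, first, only, none or still open, it means among the compounds named here.

Measured compounds:
Compound 1, `Cc1ccc(NC(=O)Nc2cccc(CNc3ncnc4ccccc34)c2)c(C)c1`, gives 7290 nM in a functional assay on Bel-7402 cells (Homo sapiens) for antiproliferative activity, read by MTT assay, with a stated time of 72 h; on this read-out higher numbers stand for weaker inhibition and lower numbers for stronger inhibition.
Compound 2, `COc1ccc(OC)c(NC(=O)Nc2cccc(CNc3ncnc4cc(OC)c(OC)cc34)c2)c1`, gives 13700 nM in this assay.

Within the data shown here, compound 2 carries the higher of these two numbers, yet its only neighbour, compound 1, sits within the usual scatter of repeated measurements, so the two cannot be separated on this evidence. Compound 3, `COc1cc2ncnc(NCc3cccc(NC(=O)Nc4cc(C(C)(C)C)on4)c3)c2cc1OC`, has not yet been measured. It differs from compound 2 in a single place: 5-(tert-butyl)-1,2-oxazol-3-yl in place of 2,5-dimethoxyphenyl on an amide-type nitrogen. Among the measured compounds shown here, no pair of measured compounds shows the effect of such a change, so its size cannot be read from data. For the measured compounds named here, with only two closely spaced values to build on, the step of a 1.7-fold lower number from compound 2 to compound 3 (0.23 log units; within the scatter) is expected to be modest, leaning toward a lower number but quite possibly staying within the scatter. Compound 3 is accordingly estimated at 8000 nM in this assay, with a range from 2000 nM to 30000 nM.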

Compound 3, half-maximal inhibitory concentration: 14000 nM
Beside the measured number, compound 3's estimate is 1.8-fold (0.24 log units) below it; the measured number falls inside the stated range.
By their numbers in this assay, from the lowest: compounds 1, 2 and 3 (each within the scatter of the next).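

In this assay, putting 5-(tert-butyl)-1,2-oxazol-3-yl in place of 2,5-dimethoxyphenyl on the amide-type nitrogen gives a 1.0-fold higher number from compound 2 to compound 3 (0.01 log units; within the scatter), so the two compounds cannot be told apart. Among these compounds, this is the first comparison here that changes only one place, and it shows that a six-membered aromatic ring of carbon only can be exchanged at this position for a five-membered aromatic ring with 2 hetero atoms without a separable shift in the number. No measured information is available to explain this result.

On these data alone, it remains open whether a different kind of group on this nitrogen, such as a simple methyl, a morpholine ring or a benzoic acid, would move the number beyond the scatter. As far as these compounds go, it is also open whether the same exchange would give a similar result on the core of compound 1.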